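A Hydroxymethyl Side Chain Replaces a Branched Alkyl

A few compounds are considered here, and "the series" means these few. Any claim that something is new, unique, unknown or untested is made for them only; others in the source may bear on it.

Of the compounds shown here, two sharing one core have been tested in a functional assay on HL-60 cells (Homo sapiens) for cytotoxicity, read by WST assay, with a stated time of 48 h; on this read-out lower numbers stand for stronger inhibition and higher numbers for weaker inhibition. Compound 1 `COc1cc(C(c2ccc(O)c(OC)c2)[C@H](C)[C@H](C)CF)ccc1O` gives 56000 nM, while compound 2 `COc1cc(C(c2ccc(O)c(OC)c2)[C@H](CC(C)C)C(C)C)ccc1O` gives 9600 nM, so compound 2 holds the lower of the two numbers, and the step of a 5.8-fold lower number from compound 1 to compound 2 (0.77 log units; beyond the scatter) shows the gap between them. Compound 3 `COc1cc(C(c2ccc(O)c(OC)c2)[C@H](C)[C@@H](C)CO)ccc1O` is the next member of the series, and it differs from compound 2 by 2-(hydroxymethyl)-1-methylpropyl in place of 1-isopropyl-3-methylbutyl on a saturated chain carbon bound to two aromatic carbons. Among the measured compounds shown here, the only measured step that bears on this change is a 5.8-fold lower number from compound 1 to compound 2 (0.77 log units; beyond the scatter), which shows that removing the larger branched chain in favour of a shorter one carrying a fluoromethyl group weakened the effect. Compound 3 carries a similar short chain, now bearing a hydroxyl, so a move back toward the number of compound 1 is expected, namely a 6.3-fold higher number from compound 2 to compound 3 (0.80 log units; beyond the scatter). Compound 3 is therefore estimated at 60000 nM, within a range from 20000 nM to 180000 nM.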

Compound 3, half-maximal inhibitory concentration: > 100000 nM
Compound 3 was reported as a limit; the forecaster's own chance of this, stated with the estimate: 20%; middle value at least 1.6-fold (0.22 log units) away from the limit.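

Compound 3 is reported only as a limit, not as a measured number: the limit of > 100000 nM in this assay, at which 1 of the 3 values shown sits. Even so, placing 2-(hydroxymethyl)-1-methylpropyl instead of 1-isopropyl-3-methylbutyl on this saturated chain carbon brings a large loss (an at least 10-fold higher number from compound 2 to compound 3 (1.01 log units; beyond the scatter)), so a second short chain now follows the weaker direction already seen with the fluorinated chain of compound 1. Exchanging 1-(fluoromethyl)ethyl for 1-(hydroxymethyl)ethyl gives only a floor that lies within the scatter (an at least 1.7-fold higher number from compound 1 to compound 3 (0.25 log units; that floor lies within the scatter)), so these two short chains cannot be ranked against each other.

On these data alone, what remains open is whether the loss follows the shorter chain or the atom at its end, since compound 2 differs from both others in chain and end group alike. A short chain ending in an amine, or a longer chain ending in a hydroxyl, would help to separate these two changes.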